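The compounds below may be only part of what the source reports. "The series", "measured", "known", "first", "only" and "open" are said of these compounds alone.

Measured compounds:
- Compound 1, `O=C(NCCCCc1ccccc1)n1c(=O)oc2ccccc21`: 64 nM
- Compound 2, `Cc1ccc2c(c1)oc(=O)n2C(=O)NCCCCc1ccccc1`: 66 nM
- Compound 3, `O=C(NCCCCc1ccccc1)n1c(=O)oc2cc(F)ccc21`: 31 nM

All three were tested in an assay on HEK293 cells for inhibition of acid ceramidase (Homo sapiens), with a stated time of 10 min; a lower number here means a stronger inhibitor, a higher number a weaker inhibitor. Compound 1 stands second highest of the three numbers; compound 2 sits closest to it, with a 1.0-fold higher number from compound 1 to compound 2 (0.01 log units; within the scatter), while compound 3 is furthest, with a 2.1-fold lower number from compound 1 to compound 3 (0.31 log units; beyond the scatter). Between the other two, a 2.1-fold lower number from compound 2 to compound 3 (0.33 log units; beyond the scatter).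

Compound 4, `Cc1cccc2c1oc(=O)n2C(=O)NCCCCc1ccccc1`, has not yet been measured. Compared with compound 1, the change is methyl in place of hydrogen on an aromatic carbon. The place differs from that of the methyl in compound 2, which sits elsewhere on the same ring.

Going by the values given here, the step that bears most directly on this change is the one from compound 1 to compound 2, where a methyl also replaced a hydrogen on an aromatic carbon of the shared core, and it stayed within the scatter. The steps involving compound 3 concern a fluoro, not a methyl, so they say less about compound 4. Among the compounds with values here, with only one methyl step to go by, the expectation is that adding the methyl at this new place gives a number that is not beyond the scatter from compound 1, in either direction, so a 1.0-fold higher number from compound 1 to compound 4 (0.01 log units; within the scatter) is expected.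

Compound 4 is therefore estimated at 65 nM, with a range of 30 nM to 140 nM.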

Compound 4, half-maximal inhibitory concentration: 23 nM
Compound 4: middle estimate off by 2.8-fold (0.45 log units), on the high side, outside the stated range (below it).
By their numbers in this assay, from the lowest: compounds 4 and 3 (each within the scatter of the next); then compounds 1 and 2 (each within the scatter of the next).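

In this assay methyl in place of hydrogen, ortho to a fused ring and meta to a fused ring, gives a 2.8-fold lower number from compound 1 to compound 4 (0.44 log units; beyond the scatter) and so moves the number beyond the scatter. The same kind of swap at the other place on this ring gave a 1.0-fold higher number from compound 1 to compound 2 (0.01 log units; within the scatter) and stayed within the scatter, so on this core the outcome of adding a methyl depends on where it sits, and one methyl step cannot stand in for another. Nothing available here gives a measured reason for this difference between the two places.

From the compounds shown here alone, whether the lower number is special to methyl remains open, since a chloro group, a methoxy group or a longer chain such as ethyl at this same place could go either way. Also open, going by these compounds, is what happens when this methyl is combined on the shared core with the fluoro of compound 3, as the two changes might add up or might not.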